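From methoxycarbonyl to hydroxy: compound 1 and compound 4

The compounds below may be only part of what the source reports. "The series", "measured", "known", "first", "only" and "open" are said of these compounds alone.

Measured in an ADME assay on ECV-304 cells (Homo sapiens) for cytotoxicity, read by MTT assay, with a stated time of 72 h; on this read-out higher numbers stand for weaker inhibition and lower numbers for stronger inhibition:
- compound 1 `COC(=O)c1cc(C2=C(c3cc(OC)c(OC)c(OC)c3)C(=O)CC2O[SiH2]C(C)(C)C)ccc1OC` gives > 100 ug/mL
- compound 2 `COc1ccc(C2=C(c3cc(OC)c(OC)c(OC)c3)CC(O[SiH2]C(C)(C)C)C2=O)cc1[N+](=O)[O-]` gives > 100 ug/mL
- compound 3 `O/N=C1/CC(O)C(c2ccccc2)=C1c1ccccc1` gives > 100 ug/mL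

Compound 1 is reported only as a limit (> 100 ug/mL). The set offers no number to work from (the limit of > 100 ug/mL in this assay, at which 3 of the 3 values shown sit). The step to compound 4 (`COc1ccc(C2=C(c3cc(OC)c(OC)c(OC)c3)C(=O)CC2O[SiH2]C(C)(C)C)cc1O`) puts hydroxy in place of methoxycarbonyl on an aromatic carbon, turning 4-methoxy-3-(methoxycarbonyl)phenyl into 3-hydroxy-4-methoxyphenyl. Going by the values given here, no measured pair shows what a single change does here. In this assay the expected direction is toward stronger inhibition, though compound 4 may also stay at the limit, since compound 1 offers only its limit (> 100 ug/mL) as a starting point. This is an expected move (an at least 10-fold lower number from compound 1 to compound 4 (1.00 log units; beyond the scatter)), and a loosely estimated one. Compound 4 is estimated at 10 ug/mL, within an expected range from 0.1 ug/mL to 100 ug/mL.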

Compound 4, half-maximal inhibitory concentration: 30 ug/mL
Compound 4: the middle estimate sits 3.0-fold (0.48 log units) below what was measured; the measured number falls inside the stated range.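

In this assay, putting hydroxy in place of methoxycarbonyl on an aromatic carbon ortho to a methoxy group brings an at least 3.3-fold lower number from compound 1 to compound 4 (0.52 log units; beyond the scatter). This shows that a change at this one position can bring measurable cytotoxicity, with compound 4 giving 30 ug/mL. The step is only a minimum, and compound 4 alone stands clear of the limit: the limit of > 100 ug/mL in this assay, at which 3 of the 4 values shown sit.

As far as these compounds go, it stays open whether the step comes from gaining hydroxy or from losing methoxycarbonyl. From the compounds shown here alone, what an amine or a carboxylic acid would give in the same place also remains unknown.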